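The source may report more compounds than this note shows. Statements on the series, on what has been measured and on what is new or still open speak of the compounds shown alone.

Measured compounds, all in a functional assay on P388 cells (Mus musculus) for cytotoxicity, read by MTT assay, with a stated time of 72 h; on this read-out lower numbers stand for stronger inhibition and higher numbers for weaker inhibition:

Compound 1, `C=CC(C)(C)c1[nH]c2ccc(C[C@@H](Cl)C(C)(C)O)cc2c1/C=C1\NC(=O)[C@H](C)NC1=O`: > 50000 nM, a limit of the assay rather than a number.
Compound 2, `C=CC(C)(C)c1[nH]c2ccc(C[C@@H](O)C(=C)C)cc2c1/C=C1\NC(=O)[C@H](C)NC1=O`: > 50000 nM, again a limit rather than a number.
Compound 3, `C=CC(C)(C)c1[nH]c2c(C[C@@H](O)C(C)(C)Cl)cccc2c1/C=C1\NC(=O)[C@H](C)NC1=O`: > 50000 nM, also a limit rather than a number.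

Compound 3 therefore stands where every measured compound stands: at the limit, with no number of its own. Within the data shown here, the only comparison between measured compounds, a step that the two limits leave unreadable from compound 1 to compound 2, is unreadable, since both ends sit at a limit; the limit of > 50000 nM in this assay, at which 3 of the 3 values shown sit, shows that nothing in this set moves off that limit.

Compound 4, `C=CC(C)(C)c1[nH]c2c(CC=C(C)C)cccc2c1/C=C1\NC(=O)[C@H](C)NC1=O`, is not yet measured. It differs from compound 3 as follows: 2-methylprop-1-en-1-yl in place of 2-chloro-1-hydroxy-2-methylpropyl on a saturated chain carbon bound to an aromatic carbon. So the 2-chloro-1-hydroxy-2-methylpropyl group on the saturated chain carbon bound to an aromatic carbon is replaced by a 2-methylprop-1-en-1-yl group.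

Among the measured compounds shown here, no measured step bears on this change, and the data give no direction. The expectation is that a step that the limit leaves unreadable from compound 3 to compound 4 shows nothing beyond the scatter, with compound 4 most likely again at the limit. Compound 4 is estimated at 70000 nM, in the range 20000 nM to 250000 nM.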

Compound 4, half-maximal inhibitory concentration: > 50000 nM
Compound 4: no number, only a limit (the forecaster's own chance of this, stated with the estimate: 85%); the middle value does not contradict the limit.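

In this assay, among these compounds, compound 3 and compound 4 both give a limit rather than a number, so no step between them can be read: the limit of > 50000 nM in this assay, at which 4 of the 4 values shown sit.

The compounds shown leave open whether any change to the shared core would move a compound off that limit, and by how much.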